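The source may hold more compounds than are shown below. What is called first, only, known or untested is meant among the compounds shown, and "the series" means these compounds.

Measured compounds in the series:
- compound 1 `COc1cccc(CNC(=O)c2cn(C)c3nc(-c4cn[nH]c4)ccc23)c1`: < 1 nM
- compound 2 `COc1cccc(CN(C(=O)c2c[nH]c3nc(-c4cn[nH]c4)ccc23)C2CC2)c1`: 30 nM
- compound 3 `COc1cccc(CN(CCCN2CCN(C)CC2)C(=O)c2c[nH]c3nc(-c4cn[nH]c4)ccc23)c1`: 260 nM

Notes. In an assay on isolated protein for inhibition of Rho-associated protein kinase 1 (Homo sapiens) (on this read-out higher numbers stand for weaker inhibition and lower numbers for stronger inhibition), compound 3 gives 260 nM, the highest of the two numbers recorded; its nearest neighbour is compound 2, which in this assay gives 30 nM. For compound 1 the value in this assay is a limit of the assay and not a number (the limit of < 1 nM in this assay, at which 1 of the 3 values shown sits), so it is set aside for comparisons of size.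

Compound 4 `CCN(Cc1cccc(OC)c1)C(=O)c1c[nH]c2nc(-c3cn[nH]c3)ccc12` is not yet measured. It differs from compound 3 by hydrogen in place of (4-methylpiperazin-1-yl)methyl on a saturated chain carbon, two bonds along the chain from an amide-type nitrogen.

For the measured compounds named here, the one measured step that bears on this is an 8.7-fold higher number from compound 2 to compound 3 (0.94 log units; beyond the scatter), where the same chain was introduced in place of cyclopropyl on the amide-type nitrogen and the number rose. Compound 4 carries ethyl on that nitrogen, a small group closer in size to the cyclopropyl of compound 2 than to the long chain of compound 3. The step from compound 3 to compound 4 is therefore expected to run the other way, roughly undoing the rise seen from compound 2 to compound 3, giving a lower number in this assay, with the step estimated at a 6.5-fold lower number from compound 3 to compound 4 (0.81 log units; beyond the scatter).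

For compound 4 the value in this assay is estimated at 40 nM, expected to lie between 12 nM and 130 nM.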

Compound 4, half-maximal inhibitory concentration: 76 nM
Beside the measured number, compound 4's estimate is 1.9-fold (0.28 log units) below it; measured number inside the range.
By their numbers in this assay, from the lowest: compound 2; then compound 4; then compound 3. At a limit, below all of these: compound 1.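

Removing the (4-methylpiperazin-1-yl)methyl from the chain gives, in this assay, a 3.4-fold lower number from compound 3 to compound 4 (0.53 log units; beyond the scatter) and so links part of the higher number of compound 3 to the portion of the chain that leaves, not merely to the presence of a chain on the amide-type nitrogen. Ethyl and cyclopropyl are also not interchangeable at this position, as the earlier compounds could not show, with a 2.5-fold higher number from compound 2 to compound 4 (0.40 log units; beyond the scatter) printed as beyond the scatter, so even small groups on this nitrogen separate in this read-out. Nothing at hand gives a measured reason for either step.

Still open, as far as these compounds go, is whether the number of compound 3 depends on the piperazine ring itself or on chain length, a question that a plain propyl or a 3-(dimethylamino)propyl on the same nitrogen would address. Also open, from the compounds shown here alone, is how methyl or the amide hydrogen would read on this nitrogen with the core of compound 2, as compound 1 carries that hydrogen but differs in a second place, and its value is a limit.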